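This account rests on a few compounds, and the source may have more. Where it says the series, first, only, none or still open, it means among the compounds named here.

Of the compounds shown here, three have been tested in a functional assay on A-375 cells (Homo sapiens) for inhibition, read by MTT assay, with a stated time of 120 h (on this read-out higher numbers stand for weaker inhibition and lower numbers for stronger inhibition), and a fourth awaits testing. Compound 3 `CC(NC(=O)C#Cc1ccc(NC(=O)Nc2ccc(Cl)c(C(F)(F)F)c2)cc1)c1ccccc1` gives 16800 nM in this assay. Within the data shown here, compound 1 `CC(NC(=O)C#Cc1ccc(NC(=O)Nc2cc(C(F)(F)F)ccc2Cl)cc1)c1ccccc1` shares its core; the one change between them is 2-chloro-5-(trifluoromethyl)phenyl in place of 4-chloro-3-(trifluoromethyl)phenyl on an amide-type nitrogen, and in this assay it made a 1.8-fold higher number from compound 3 to compound 1 (0.26 log units; within the scatter). In this assay compound 1 gives 30500 nM. Compound 2 `CC(NC(=O)/C=C/c1ccc(NC(=O)Nc2ccc(Cl)c(C(F)(F)F)c2)cc1)c1ccccc1` rests on a different core, and the difference between the two cores is not broken down here; in this assay compound 2 gives 20800 nM. The values of compounds 2 and 3 lie within the usual scatter of each other, as do those of compounds 2 and 1, so no order can be read among the three measured compounds.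

Compound 4 `CC(NC(=O)/C=C/c1ccc(NC(=O)Nc2cc(C(F)(F)F)ccc2Cl)cc1)c1ccccc1` has not yet been measured. It stands to compound 2 as compound 1 stands to compound 3: the change is 2-chloro-5-(trifluoromethyl)phenyl in place of 4-chloro-3-(trifluoromethyl)phenyl on an amide-type nitrogen, the same change at the same kind of place as before. Among the measured compounds shown here, only one earlier example of this change exists, and that one stayed within the scatter, so the expectation rests on a single step. The expected step in this assay is a 1.4-fold higher number from compound 2 to compound 4 (0.16 log units; within the scatter). This expectation rests on compound 3 and compound 1, whose change made a 1.8-fold higher number from compound 3 to compound 1 (0.26 log units; within the scatter). Compound 4 is therefore estimated to give about 30000 nM in this assay, with a plausible range from 12000 nM to 75000 nM.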

Compound 4, half-maximal inhibitory concentration: 40900 nM
For compound 4 the middle estimate is 1.4-fold (0.13 log units) below the measured one, within the range that was stated.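

In this assay, putting 2-chloro-5-(trifluoromethyl)phenyl in place of 4-chloro-3-(trifluoromethyl)phenyl on the amide-type nitrogen of a second core gives a 2.0-fold higher number from compound 2 to compound 4 (0.29 log units; within the scatter). The same swap has now been read on two cores, and the two steps agree: the same change on two cores in this assay, a 1.8-fold higher number (0.26 log units; within the scatter) from compound 3 to compound 1 and a 2.0-fold higher number (0.29 log units; within the scatter) from compound 2 to compound 4, 1.1-fold (0.03 log units) apart, within the scatter of two such steps. This shows that, so far in this series, the swap has carried from one core to the other with a step of similar size, but each step lies within the scatter on its own, so the pair does not establish that the swap truly alters inhibition, and two cores are too few to make a rule for the series.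

The compounds shown leave open whether a methoxy group or a nitrile in place of the chlorine, or an amine or a carboxylic acid elsewhere in the molecule, would move the number in this assay beyond the scatter. They also leave open whether this swap would behave in the same way on any core other than these two, and whether it would do so in any other assay.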